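The source may report more compounds than this note shows. Statements on the series, on what has been measured and on what is new or still open speak of the compounds shown alone.

Compound 2 `COc1cc(Br)cc(/C=C/C(=O)c2ccc(C)cc2)c1O` stands highest of the two numbers obtained so far in a functional assay on MCF7 cells (Homo sapiens) for antiproliferative activity, read by sulforhodamine B assay, with a stated time of 72 h, tested at 30 uM (a higher number here means a weaker effect of the compound at the concentration tested, a lower number a stronger effect), where compound 2 gives 61.5%. Its nearest neighbour is compound 1 `COc1cc(Br)cc(/C=C/C(=O)c2ccc(Cl)cc2)c1O`, which in this assay gives 28%. For the measured compounds named here, the single measured step between the two, a number 33.5 percentage points higher from compound 1 to compound 2 (beyond the scatter), is the only one that bears on the change now in question. Compound 3 `COc1cc(Br)cc(/C=C/C(=O)c2ccc(Br)cc2)c1O` differs from compound 2 in one place, (bromo in place of methyl on an aromatic carbon), on an aromatic carbon of a six-membered aromatic ring of carbon only. The step from compound 1 to compound 2 replaced chloro with methyl and moved the number well beyond the scatter; the present step replaces that methyl with bromo, another halogen, at the same aromatic carbon, so a step of roughly similar size is expected, in the opposite direction. The estimate for compound 3 in this assay is therefore 35%, with a range from 15% to 60%. That estimate means a step of a number 26.5 percentage points lower from compound 2 to compound 3 (beyond the scatter), expected to bring the number back toward that of compound 1, though bromo and chloro are not the same substituent and the range stays wide.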

Compound 3, a percentage reported as activity, at one concentration (the size of the read-out at that concentration, not a potency): 48.3%
Compound 3: middle estimate off by 13.3 percentage points, on the low side; measured number inside the range.
By their numbers in this assay, from the lowest: compound 1; then compound 3; then compound 2.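

In this assay, the change at this aromatic carbon gives a number 13.2 percentage points lower from compound 2 to compound 3 (beyond the scatter) and so shows that the large rise seen on going from chloro to methyl is not simply undone by any halogen. Chloro and bromo are not interchangeable here: bromo in place of chloro gives a number 20.3 percentage points higher from compound 1 to compound 3 (beyond the scatter) and leaves compound 3 between the other two, with compound 1 the lowest of the three and the strongest effect at the concentration tested. The order at this one position therefore runs chloro, bromo, methyl from the lowest number to the highest, but nothing at hand accounts for that order.

The compounds shown leave open where fluoro, methoxy, an amine or a carboxylic acid would fall at this carbon, and whether the same order would hold if the bromo or the methoxy of the shared core were replaced. These are also read-outs at a single concentration, so how the three compounds would rank in potency remains an open question.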